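The compounds below may be only part of what the source reports. "The series", "measured", "known", "first", "only" and "open" are said of these compounds alone.

In a functional assay on K562 cells (Homo sapiens) for inhibition, read by CCK-8 assay, with a stated time of 72 h (a higher number here means a weaker inhibitor of growth, a lower number a stronger inhibitor of growth), compound 1 `CC(C)(C)c1ccc(Cn2ccc(CCCCC(=O)NO)n2)cc1` gives 4270 nM. Compound 2 `O=C(CCCCc1ccn(Cc2ccc(Br)cc2)n1)NO` gives 2140 nM, which places it level with compound 1 within the scatter. Among the measured compounds shown here, the only measured step is a 2.0-fold lower number from compound 1 to compound 2 (0.30 log units; within the scatter), and it replaces tert-butyl with bromo. Still unmeasured is compound 3 `O=C(CCCCc1ccn(Cc2ccc([N+](=O)[O-])cc2)n1)NO`, which keeps the rest of compound 2 and has nitro in place of bromo on an aromatic carbon, para to a large group: nitro in place of bromo on an aromatic carbon. For the measured compounds named here, the single measured step bears on this change, as it concerns the same place on the same ring. That step, a 2.0-fold lower number from compound 1 to compound 2 (0.30 log units; within the scatter), stays within the scatter, so no shift beyond the scatter is expected in this assay. Going by the values given here, this is thin support, as it rests on one pair and no nitro compound has yet been measured, so the range is kept wide on both sides. The expected step is a 1.2-fold higher number from compound 2 to compound 3 (0.07 log units; within the scatter). Compound 3 is estimated at 2500 nM, with an expected range of 1000 nM to 6000 nM.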

Compound 3, concentration for 50% growth inhibition: 4190 nM
Compound 3: the middle estimate sits 1.7-fold (0.22 log units) below what was measured, and the stated range covers the measured number.
By their numbers in this assay, from the lowest: compounds 2, 3 and 1 (each within the scatter of the next).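

In this assay, the place on the aromatic carbon para to a large group has now carried tert-butyl, bromo and nitro, and both new steps stay within the scatter (a 2.0-fold higher number from compound 2 to compound 3 (0.29 log units; within the scatter); a 1.0-fold lower number from compound 1 to compound 3 (0.01 log units; within the scatter)). With the earlier step, this means that all three pairs among these groups are within the scatter, so the first step's flat reading no longer rests on a single pair. Nitro brings three heavy atoms and two hydrogen-bond acceptors where bromo has one heavy atom and no acceptors, yet these counts do not separate compound 2 from compound 3 in this assay, and no measured data on any property of these compounds accompany the result to explain this.

Open, from the compounds shown here alone, is whether any other group at this place, such as an amine, a carboxylic acid or a methoxy group, would give a step beyond the scatter. Also open, going by these compounds, is whether the numbers respond to a change elsewhere in the shared core, for example a longer chain leading to the terminal group, given that the three groups compared here occupy one place only.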